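This account rests on a few compounds, and the source may have more. Where it says the series, first, only, none or still open, it means among the compounds named here.

Among the measured compounds shown here, in a functional assay on NCI-H322 cells (Homo sapiens) for cytotoxicity, read by MTT assay, with a stated time of 24 h (on this read-out higher numbers stand for weaker inhibition and lower numbers for stronger inhibition), compound 1, whose structure is `COc1ccc(/C=C\C(=O)O)c(OCc2cn(-c3ccccc3F)nn2)c1CC=C(C)C`, gives 45600 nM, the highest of the three numbers measured so far. Compound 2, `COc1ccc(/C=C\C(=O)O)c(OCc2cn(-c3ccccc3)nn2)c1CC=C(C)C`, gives 29200 nM, and compound 3, `COc1ccc(/C=C\C(=O)O)c(OCc2cn(-c3nc4ccccc4s3)nn2)c1CC=C(C)C`, gives 23000 nM. Compound 4, `COc1ccc(/C=C\C(=O)O)c(OCc2cn(-c3cccc([N+](=O)[O-])c3)nn2)c1CC=C(C)C`, has not yet been measured; it differs from compound 1 by 3-nitrophenyl in place of 2-fluorophenyl on an aromatic nitrogen, the change sitting on an aromatic nitrogen of a five-membered aromatic ring with 3 nitrogen, next to the ring nitrogen. The measured steps that bear on this change are the ones that also vary the group on that aromatic nitrogen: a 1.6-fold lower number from compound 1 to compound 2 (0.19 log units; within the scatter) and a 2.0-fold lower number from compound 1 to compound 3 (0.30 log units; within the scatter), and the step of a 1.3-fold lower number from compound 2 to compound 3 (0.10 log units; within the scatter) between those two variants is likewise within the scatter. Every exchange of the group on that nitrogen seen so far has therefore left the read-out essentially where it was. For compound 4 the step of a 1.3-fold lower number from compound 1 to compound 4 (0.11 log units; within the scatter) is expected to stay within the scatter. Compound 4 is estimated to give 35000 nM in this assay, with a range from 15000 nM to 80000 nM.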

Compound 4, half-maximal inhibitory concentration: 43200 nM
Compound 4: middle estimate off by 1.2-fold (0.09 log units), on the low side, within the range that was stated.
By their numbers in this assay, from the lowest: compounds 3, 2, 4 and 1 (each within the scatter of the next).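

In this assay, the group on the aromatic nitrogen now also covers 3-nitrophenyl, which adds 2 hydrogen-bond acceptors to a group that had none in 2-fluorophenyl, and the exchange gives a 1.1-fold lower number from compound 1 to compound 4 (0.02 log units; within the scatter). Nitro in place of hydrogen on an aromatic carbon gives a 1.5-fold higher number from compound 2 to compound 4 (0.17 log units; within the scatter), and 3-nitrophenyl in place of 1,3-benzothiazol-2-yl gives a 1.9-fold higher number from compound 3 to compound 4 (0.27 log units; within the scatter), so all four compounds now lie within the scatter of one another, and this position has shown no step beyond it. Nothing at hand explains why the read-out stays so flat.

On these data alone, it remains open whether an amine or a carboxylic acid on that phenyl ring, or a simple alkyl chain on the aromatic nitrogen in place of the aromatic group, would move the number. The compounds also leave open whether changes elsewhere on the shared core would do so.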